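Swapping a side chain: from compound 1 to compound 3

A few compounds are considered here, and "the series" means these few. Any claim that something is new, unique, unknown or untested is made for them only; others in the source may bear on it.

Of the compounds shown here, two have been measured in a functional assay on the whole organism (Tail, strain ICR) with Mus musculus as the target, in the tail flick test, with a stated time of 120 min, at a dose of 25 umol/kg by the oral route; on this read-out higher numbers stand for a stronger effect at the one dose given and lower numbers for a weaker effect. Compound 1 `NC(=O)C[C@H](NC(=O)CN(c1nc(Cl)nc2[nH]cnc12)C1CC1)C(=O)O` gives 17%, the lower of the two numbers. Compound 2 `CC(C)(C)OC(=O)NCCCC[C@H](NC(=O)CN(c1ncnc2c1ncn2C1CCCCO1)C1CC1)C(=O)OCc1ccccc1` gives 28.4%, a gap beyond the usual scatter. Compound 3 `CC(C)[C@H](NC(=O)CN(c1nc(Cl)nc2[nH]cnc12)C1CC1)C(=O)O` is not yet measured; it differs from compound 1 by isopropyl in place of carbamoylmethyl on a saturated chain carbon bound to an amide-type nitrogen and a carbonyl carbon. Among the measured compounds shown here, since no measured pair shows this change, the step is expected to be small and unknown in direction: the estimated change a number 5 percentage points higher from compound 1 to compound 3 (within the scatter) is likely to fall within the scatter. Compound 3 is therefore expected to give about 22%, within a range from 8% to 40%.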

Compound 3, a percentage reported as activity, at one dose (the size of the read-out at that dose, not a potency): 17.1%
Estimate against measurement, compound 3: 4.9 percentage points above, within the range that was stated.
By their numbers in this assay, from the lowest: compounds 1 and 3 (each within the scatter of the next); then compound 2.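

In this assay, putting isopropyl in place of carbamoylmethyl on a saturated chain carbon bound to an amide-type nitrogen and a carbonyl carbon gives a number 0.1 percentage points higher from compound 1 to compound 3 (within the scatter). Among the compounds shown here, this is the first one-place comparison, and at this one dose the read-out does not separate the two side chains, although only carbamoylmethyl carries a hydrogen-bond donor and acceptor. No further data bear on why this is so. From the compounds shown here alone, whether an amine, a carboxylic acid or a longer carbon chain at this place would move the read-out remains open. A single dose also leaves any difference in potency unresolved.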